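Working notes: from compound 3 to compound 4

The compounds below may be only part of what the source reports. "The series", "measured", "known", "first", "only" and "open" are said of these compounds alone.

Measured in a functional assay on HeLa cells (Homo sapiens) for antiproliferative activity, read by MTT assay, with a stated time of 48 h; a lower number here means a stronger inhibitor, a higher number a weaker inhibitor:
- compound 1 `CCOc1cc(-c2ccc3[nH]ccc3c2)cn2c(-c3cc(OC)c(OC)c(OC)c3)nnc12`: 166 nM
- compound 2 `COc1cc(-c2nnc3c(OC)cc(-c4ccc5[nH]ccc5c4)cn23)cc(OC)c1OC`: 85 nM
- compound 3 `COc1cc(-c2nnc3c(OCC(F)(F)F)cc(-c4ccc5[nH]ccc5c4)cn23)cc(OC)c1OC`: 348 nM

Compound 3 has the highest number of the three, 348 nM. Its two steps are a 2.1-fold higher number from compound 1 to compound 3 (0.32 log units; beyond the scatter) and a 4.1-fold higher number from compound 2 to compound 3 (0.61 log units; beyond the scatter). The next change leads to compound 4 `COc1cc(-c2nnc3c(OC4CN(C(C)(C)C)C4)cc(-c4ccc5[nH]ccc5c4)cn23)cc(OC)c1OC`: 1-(tert-butyl)azetidin-3-yl in place of 2,2,2-trifluoroethyl on an oxygen on an aromatic ring, (1-(tert-butyl)azetidin-3-yl in place of 2,2,2-trifluoroethyl on an oxygen on an aromatic ring). All three measured steps bear on this change, since each alters the group on that oxygen. The third is a 2.0-fold lower number from compound 1 to compound 2 (0.29 log units; within the scatter). These steps are small to modest, and none brings in a ring or a nitrogen, so they offer only a weak guide. In this assay, a small upward step is expected, with no confident move beyond the scatter. The expected change is a 1.4-fold higher number from compound 3 to compound 4 (0.16 log units; within the scatter). Compound 4 is estimated at 500 nM, with an expected range of 130 nM to 1900 nM.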

Compound 4, half-maximal inhibitory concentration: > 10000 nM
Compound 4: no number, only a limit; the forecaster's own chance of this, stated with the estimate: 4%; middle value at least 20-fold (1.30 log units) from the limit.
By their numbers in this assay, from the lowest: compounds 2 and 1 (each within the scatter of the next); then compound 3. At a limit, above all of these: compound 4.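

In this assay compound 4 gives > 10000 nM and this value is a limit of the assay, not a number. Putting 1-(tert-butyl)azetidin-3-yl on the oxygen gives an at least 28-fold higher number from compound 3 to compound 4 (1.45 log units; beyond the scatter) and, set against the smaller groups on the same oxygen, an at least 110-fold higher number from compound 2 to compound 4 (2.07 log units; beyond the scatter) and an at least 60-fold higher number from compound 1 to compound 4 (1.77 log units; beyond the scatter) in turn. Among methyl, ethyl and 2,2,2-trifluoroethyl the largest step was only a 4.1-fold higher number from compound 2 to compound 3 (0.61 log units; beyond the scatter) so the position accepts those three chains in this assay but does not accept every group on this oxygen.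

The compounds shown leave open whether the loss follows the four-membered ring, its nitrogen or the tert-butyl group. An unsubstituted azetidin-3-yl, a cyclobutyl group or a longer chain ending in an amine on the same oxygen would separate these.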